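Fluoro on the phenyl of the methoxy analogue

A few compounds are considered here, and "the series" means these few. Any claim that something is new, unique, unknown or untested is made for them only; others in the source may bear on it.

Compound 1 `Clc1ccc(C2=NN(c3ccc(-c4ccccc4)nn3)C(c3ccccc3)C2)cc1` gives 10000 nM in a functional assay on MCF7 cells (Homo sapiens) for antiproliferative activity, read by MTT assay, with a stated time of 24 h; on this read-out higher numbers stand for weaker inhibition and lower numbers for stronger inhibition. Compound 2 `Fc1ccc(C2CC(c3ccc(Cl)cc3)=NN2c2ccc(-c3ccccc3)nn2)cc1`, which carries fluoro on the phenyl, gives 3750 nM; the step of a 2.7-fold lower number from compound 1 to compound 2 (0.43 log units; beyond the scatter). Compound 3 `COc1ccc(C2=NN(c3ccc(-c4ccccc4)nn3)C(c3ccccc3)C2)cc1` has methoxy where compound 1 has chloro. In this assay compound 3 reaches only a limit of the assay, > 100000 nM, and no number. The step of an at least 10-fold higher number from compound 1 to compound 3 (1.00 log units; beyond the scatter) places compound 3 at the high end of the numbers shown, sitting at the limit of > 100000 nM in this assay, at which 1 of the 3 values shown sits.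

Compound 4 `COc1ccc(C2=NN(c3ccc(-c4ccccc4)nn3)C(c3ccc(F)cc3)C2)cc1` differs from compound 3 by fluoro in place of hydrogen on an aromatic carbon. For the measured compounds named here, the one measured step of this kind is a 2.7-fold lower number from compound 1 to compound 2 (0.43 log units; beyond the scatter), made on the chloro pair and starting from a measured number. The methoxy pair starts from a limit, so a shift of the same size would move compound 4 only to the edge of what this assay reports, and a further limit is a real possibility. Compound 4 is therefore expected to give about 80000 nM, within a range of 25000 nM to 300000 nM. The expected step of an at least 1.2-fold lower number from compound 3 to compound 4 (0.09 log units; that floor lies within the scatter) is a modest lowering, read against a starting point that is itself a limit.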

Compound 4, half-maximal inhibitory concentration: 20000 nM
Beside the measured number, compound 4's estimate is 4.0-fold (0.60 log units) above it; measured number outside the range, below it.
By their numbers in this assay, from the lowest: compound 2; then compounds 1 and 4 (each within the scatter of the next). At a limit, above all of these: compound 3.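

Fluoro in place of hydrogen, on an aromatic carbon para to a large group, now has a measured end on the methoxy side in this assay, with an at least 5.0-fold lower number from compound 3 to compound 4 (0.69 log units; beyond the scatter), so the lowering seen with chloro is not confined to that core. The change therefore runs in the same direction on both pairs, though its size on the methoxy pair is only a floor: the same change on two cores in this assay, a 2.7-fold lower number (0.43 log units; beyond the scatter) from compound 1 to compound 2 and an at least 5.0-fold lower number (0.69 log units; beyond the scatter) from compound 3 to compound 4; the limit leaves it open whether they differ

Methoxy in place of chloro also gains a reading with a measured number at both ends, a 5.3-fold higher number from compound 2 to compound 4 (0.73 log units; beyond the scatter), and this keeps the direction of the earlier step, which ended at a limit: the same change on two cores in this assay, an at least 10-fold higher number (1.00 log units; beyond the scatter) from compound 1 to compound 3 and a 5.3-fold higher number (0.73 log units; beyond the scatter) from compound 2 to compound 4; the limit leaves it open whether they differ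

Still open, on these data alone, is whether the lowering belongs to fluoro itself or would also follow from chloro, hydroxy or an amine on the same aromatic carbon. Also open, as far as these compounds go, is whether an ethoxy or a carboxylic acid in place of methoxy would give numbers closer to those of the chloro compounds, or whether the chloro compounds remain lower than all such replacements.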